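Swapping Chloro for Methoxy at Low Growth Inhibition

The source may report more compounds than this note shows. Statements on the series, on what has been measured and on what is new or still open speak of the compounds shown alone.

In a functional assay on KB cells (Homo sapiens) for inhibition, read by MTT assay, with a stated time of 24 h, tested at 1 ug/mL (on this read-out higher numbers stand for more inhibition of growth at the one concentration tested and lower numbers for less inhibition of growth), the three measured compounds all give modest numbers. Compound 1 (`O=C(CCCCC1CCSS1)Nc1ccc(OC(F)(F)F)cc1`) gives 1.54%, compound 2 (`O=C(CCCCC1CCSS1)Nc1cccc2ccccc12`) gives 8.37%, and compound 3 (`O=C(CCCCC(S)CCS)Nc1ccc(Cl)cc1`) gives 13.4%. Compound 3 thus stands within the scatter of compound 2 and beyond the scatter above compound 1. Compound 4 (`COc1ccc(NC(=O)CCCCC(S)CCS)cc1`) has methoxy in place of chloro on an aromatic carbon, para to a large group: methoxy in place of chloro on an aromatic carbon. Among the compounds with values here, no measured pair shows this change, so the data offer no direct guide, and no step beyond the scatter is expected in this assay. The expected step is a number 3.4 percentage points lower from compound 3 to compound 4 (within the scatter). Compound 4 is estimated at 10%, with an expected range of 2% to 22%.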

Compound 4, percent growth inhibition at one concentration: 2.49%
Compound 4: middle estimate off by 7.5 percentage points, on the high side, within the range that was stated.
By their numbers in this assay, from the lowest: compounds 1, 4, 2 and 3 (each within the scatter of the next, the first and the last beyond it).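

Methoxy in place of chloro on an aromatic carbon, para to a large group, gives a number 10.9 percentage points lower from compound 3 to compound 4 (beyond the scatter) in this assay, so this change at this position does alter the read-out. Within the data shown here, it is the only step between measured compounds that differ in one place. Nothing measured here bears on why the number falls. Going by these compounds, whether an amine or a hydroxyl at this position would stay near compound 3 or near compound 4 remains open. Also open, on these data alone, is whether methoxy in place of chloro gives a similar step on the core of compound 1.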